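The source may report more compounds than this note shows. Statements on the series, on what has been measured and on what is new or still open speak of the compounds shown alone.

For the measured compounds named here, in a functional assay on HepG2 cells (Homo sapiens) for antiproliferative activity, read by MTT assay, with a stated time of 24 h (on this read-out lower numbers stand for stronger inhibition and higher numbers for weaker inhibition), compound 1 `C#CCOc1ccc2c(=O)c(-c3cc(OC)c(OC)cc3OC)coc2c1` gives 4950 nM and compound 2 `COc1cc(OC)c(-c2coc3cc(OCc4ccccc4F)ccc3c2=O)cc1OC` gives 1280 nM, the lower of the two numbers measured so far. Going by the values given here, the only measured step, a 3.9-fold lower number from compound 1 to compound 2 (0.59 log units; beyond the scatter), is modest and lies beyond the scatter. It puts 2-fluorophenyl in place of ethynyl on a saturated chain carbon bound to an oxygen on an aromatic ring. Compound 3 `COc1cc(OC)c(-c2coc3cc(OCc4ccc([N+](=O)[O-])cc4)ccc3c2=O)cc1OC` changes that same place again, with 4-nitrophenyl in place of 2-fluorophenyl on a saturated chain carbon bound to an oxygen on an aromatic ring. Here one six-membered aromatic ring of carbon only replaces another, and no measured step shows such a swap. A change smaller than a 3.9-fold lower number from compound 1 to compound 2 (0.59 log units; beyond the scatter) is therefore expected, with no firm direction. The expected step, a 1.2-fold higher number from compound 2 to compound 3 (0.07 log units; within the scatter), would stay within the scatter. Compound 3 is estimated at 1500 nM, with an expected range from 500 nM to 4500 nM.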

Compound 3, half-maximal inhibitory concentration: 2500 nM
Estimate against measurement, compound 3: 1.7-fold (0.22 log units) below; the measured number falls inside the stated range.
By their numbers in this assay, from the lowest: compounds 2, 3 and 1 (each within the scatter of the next, the first and the last beyond it).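

With 4-nitrophenyl on the saturated chain carbon bound to an oxygen on an aromatic ring, the result is a 2.0-fold higher number from compound 2 to compound 3 (0.29 log units; within the scatter), so these two aromatic groups are not separated on this read-out. Measured against ethynyl, 4-nitrophenyl gives a 2.0-fold lower number from compound 1 to compound 3 (0.30 log units; within the scatter), while 2-fluorophenyl gave a 3.9-fold lower number from compound 1 to compound 2 (0.59 log units; beyond the scatter), so only 2-fluorophenyl stands clear of ethynyl, and a second aromatic ring at this position does not firmly repeat that difference. No evidence is available that accounts for these numbers.

The compounds shown cannot tell whether the fluorine or the nitro group matters at all, since unsubstituted benzyl is not among them, and 2-fluorophenyl and 4-nitrophenyl differ in both the group and its place. As far as these compounds go, an amine or a carboxylic acid on the ring, or a longer chain to it, also remains open.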